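Amide aryl swap in a thiophene-fused series

This account rests on a few compounds, and the source may have more. Where it says the series, first, only, none or still open, it means among the compounds named here.

Compound 1 `NC(=O)c1c(NC(=O)c2ccccc2Cl)sc2c1CCN(Cc1c(Cl)cccc1Cl)C2`: 4850 nM
Compound 2 `Cc1ccc(C(=O)Nc2sc3c(c2C(N)=O)CCN(Cc2c(Cl)cccc2Cl)C3)cc1`: 10000 nM
Compound 3 `Cc1ccc(C(=O)Nc2sc3c(c2C(N)=O)CCN(Cc2ccc(Cl)cc2Cl)C3)cc1`: 19900 nM

In a functional assay on HL-60 cells (Homo sapiens) for antiproliferative activity, with a stated time of 24 h (on this read-out lower numbers stand for stronger inhibition and higher numbers for weaker inhibition), compound 2 stands second highest of the three numbers. Its nearest neighbour is compound 3, a step of a 2.0-fold higher number from compound 2 to compound 3 (0.30 log units; within the scatter), and compound 1 lies furthest from it, the step being a 2.1-fold higher number from compound 1 to compound 2 (0.31 log units; beyond the scatter). Compound 4 `NC(=O)c1c(NC(=O)c2cccc([N+](=O)[O-])c2)sc2c1CCN(Cc1c(Cl)cccc1Cl)C2` differs from compound 2 by 3-nitrophenyl in place of 4-methylphenyl on a carbonyl carbon. For the measured compounds named here, only the step from compound 1 to compound 2 touches the same carbonyl carbon, and it was modest. A change at that position is therefore expected to shift the number only modestly, if at all, and the direction is uncertain. Compound 4 is expected at 6000 nM, within 2500 nM to 15000 nM, a step of a 1.7-fold lower number from compound 2 to compound 4 (0.22 log units; within the scatter) from compound 2.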

Compound 4, half-maximal inhibitory concentration: 18400 nM
Compound 4: middle estimate off by 3.1-fold (0.49 log units), on the low side, and the stated range ends below it.
By their numbers in this assay, from the lowest: compound 1; then compounds 2, 4 and 3 (each within the scatter of the next).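

In this assay, a third group at this carbonyl carbon reads level with 4-methylphenyl: 3-nitrophenyl, which brings two hydrogen-bond acceptors, gives no separation beyond the scatter (a 1.8-fold higher number from compound 2 to compound 4 (0.26 log units; within the scatter)). Set against 2-chlorophenyl, the same group gives a clearer gap (a 3.8-fold higher number from compound 1 to compound 4 (0.58 log units; beyond the scatter)), so compound 1 stands apart from both compounds 2 and 4 at this position. Nothing available accounts for this. Going by these compounds, whether an aminophenyl or carboxyphenyl group here would move the number stays open, as does whether this gap holds with 2,4-dichlorophenyl on the saturated chain carbon.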